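Replacing benzylamino with hydroxy on the shared core

The source may hold more compounds than are shown below. What is called first, only, known or untested is meant among the compounds shown, and "the series" means these compounds.

Of the compounds shown here, two have numbers so far. In a functional assay on HCT-116 cells (Homo sapiens) for antiproliferative activity, read by MTT assay, with a stated time of 72 h (on this read-out lower numbers stand for stronger inhibition and higher numbers for weaker inhibition), compound 1 `CC(=O)c1nc([N+](=O)[O-])c(Sc2c(Cl)cncc2Cl)s1` gives 8450 nM, and compound 2 `CC(NCc1ccccc1)c1nc([N+](=O)[O-])c(Sc2c(Cl)cncc2Cl)s1` gives 11800 nM. These two values lie within the usual scatter of each other, so compound 2 stands level with compound 1 and neither can be ranked over the other. Among the measured compounds shown here, no measured pair differs in a single place, so the data offer no direct guide to the size of a one-place change.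

The next compound, still unmeasured, is compound 3 `CC(O)c1nc([N+](=O)[O-])c(Sc2c(Cl)cncc2Cl)s1`. It departs from compound 2 in one place: hydroxy in place of benzylamino on a saturated chain carbon bound to an aromatic carbon and a saturated chain carbon. This puts hydroxy in place of benzylamino on a saturated chain carbon bound to an aromatic carbon and a saturated chain carbon.

The only anchors in this assay are compound 1 at 8450 nM and compound 2 at 11800 nM, so the expectation stays close to them. The expected step is small, slightly towards a lower number and not beyond the scatter: a 1.2-fold lower number from compound 2 to compound 3 (0.09 log units; within the scatter). For compound 3 the estimated value is 9500 nM, with an expected range of 4000 nM to 22000 nM.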

Compound 3, half-maximal inhibitory concentration: 18600 nM
Compound 3: middle estimate off by 2.0-fold (0.29 log units), on the low side; the range from low to high includes it.
By their numbers in this assay, from the lowest: compounds 1, 2 and 3 (each within the scatter of the next, the first and the last beyond it).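

In this assay the saturated chain carbon bound to an aromatic carbon and a saturated chain carbon now has its first one-place readings. Hydroxy in place of benzylamino gives a 1.6-fold higher number from compound 2 to compound 3 (0.20 log units; within the scatter), so compound 3 stands level with compound 2 even though the six-membered aromatic ring of benzylamino has gone, while 1-hydroxyethyl in place of acetyl on an aromatic carbon gives a 2.2-fold higher number from compound 1 to compound 3 (0.34 log units; beyond the scatter), a modest step and the only one-place step so far that lies beyond the scatter. Nothing available bears on what sets the size of either step.

Still open, going by these compounds, is whether any group on this chain carbon can move the number beyond the scatter from compound 2: a primary amine, a methoxy group or a carboxylic acid would each test this, as would a longer chain in place of the methyl group. On these data alone, it is also open whether a smaller amine, such as methylamino, would stand level with benzylamino and hydroxy on the shared core.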